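Swapping sulfanyl for sulfonyl on the shared core

This account rests on a few compounds, and the source may have more. Where it says the series, first, only, none or still open, it means among the compounds named here.

In a functional assay on DU-145 cells (Homo sapiens) for inhibition, read by trypan blue exclusion, with a stated time of 96 h (a lower number here means a stronger inhibitor of growth, a higher number a weaker inhibitor of growth), compound 1 `CCOc1ccc(/C=C(/SCc2ccc(F)cc2)C(=O)c2ccc(Br)cc2)cc1OC` gives 50000 nM, the higher of two numbers, while compound 2 `Cc1ccc(S/C(=C/c2ccc[nH]2)C(=O)c2ccc(Cl)cc2)cc1` gives 10000 nM, a gap beyond the scatter. Compound 3 `CCOc1ccc(/C=C(\C(=O)c2ccc(Br)cc2)S(=O)(=O)c2ccc(C)cc2)cc1OC` carries (4-methylphenyl)sulfonyl in place of (4-fluorobenzyl)sulfanyl on a double-bonded chain carbon bound to a carbonyl carbon and a double-bonded chain carbon. Going by the values given here, no measured pair isolates this change, so the expectation is loose. A moderate move toward stronger growth inhibition is expected, a 10-fold lower number from compound 1 to compound 3 (1.00 log units; beyond the scatter). For compound 3 the estimated value is 5000 nM, with an expected range of 800 nM to 30000 nM.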

Compound 3, concentration for 50% growth inhibition: 1000 nM
Beside the measured number, compound 3's estimate is 5.0-fold (0.70 log units) above it; the range from low to high includes it.
By their numbers in this assay, from the lowest: compound 3; then compound 2; then compound 1.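

In this assay the position on a double-bonded chain carbon bound to a carbonyl carbon and a double-bonded chain carbon proves sensitive: (4-methylphenyl)sulfonyl in place of (4-fluorobenzyl)sulfanyl gives a 50-fold lower number from compound 1 to compound 3 (1.70 log units; beyond the scatter) on an otherwise unchanged core. Going by these compounds alone, this is the first step that can be read at a single place, as compound 1 and compound 2 differ in more than one. No measurement offered here accounts for the size of this step.

The change alters the sulfur group and its aromatic substituent together, so their contributions remain unseparated. From the compounds shown here alone, whether (4-fluorobenzyl)sulfonyl or a sulfonamide at this position would give a similar number remains open.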